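Two methyl groups on the amide phenyl of compound 1

The source may report more compounds than this note shows. Statements on the series, on what has been measured and on what is new or still open speak of the compounds shown alone.

Measured in a functional assay on HEK293 cells for agonist activity at D(4) dopamine receptor (Homo sapiens), read by FLIPR; a lower number here means that less compound is needed, a higher number that more compound is needed for the effect:
compound 1, `O=C(NCN1CCC(c2cccc[n+]2[O-])CC1)c1ccccc1`: 532 nM
compound 2, `O=C(CN1CCC(c2cccc[n+]2[O-])CC1)NC1CCCCC1`: 294 nM
compound 3, `CCOc1cccc(C(=O)NCN2CCC(c3cccc[n+]3[O-])CC2)c1`: 324 nM

Of these three numbers compound 1 has the highest, yet the gaps are small: compound 3 lies nearest, and the values of compound 1 and compound 2 differ by an amount that is within the usual scatter, so no order among the three can be claimed.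

Compound 4, `Cc1cc(C)cc(C(=O)NCN2CCC(c3cccc[n+]3[O-])CC2)c1`, is the new compound. Compared with compound 1 the change is 3,5-dimethylphenyl in place of phenyl on a carbonyl carbon. Among the compounds with values here, the only measured step that touches the same part of the molecule is the one from compound 1 to compound 3, where a substituent was placed on that phenyl: a 1.6-fold lower number from compound 1 to compound 3 (0.22 log units; within the scatter). A single added group on this ring therefore made no difference beyond the scatter. Within the data shown here, two methyl groups on the same ring are a change of similar kind, and nothing among the measured compounds points to a large shift in either direction.

For compound 4 the expected step is therefore a 1.3-fold lower number from compound 1 to compound 4 (0.10 log units; within the scatter), close to no change. The estimate for compound 4 in this assay is 420 nM, with a range from 150 nM to 1200 nM.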

Compound 4, half-maximal effective concentration: 90 nM
Compound 4: middle estimate off by 4.7-fold (0.67 log units), on the high side; measured number outside the range, below it.
By their numbers in this assay, from the lowest: compound 4; then compounds 2, 3 and 1 (each within the scatter of the next).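

In this assay, the phenyl on a carbonyl carbon proves to be a place where a change can move the number beyond the scatter: 3,5-dimethylphenyl in its place gives a 5.9-fold lower number from compound 1 to compound 4 (0.77 log units; beyond the scatter). The only earlier step on this ring, the addition of ethoxy, gave a 1.6-fold lower number from compound 1 to compound 3 (0.22 log units; within the scatter), so until now nothing had shown that this ring responds to what it carries. Nothing in the available data accounts for the larger step, so this remains an observation about these compounds and not an explanation.

Going by these compounds, it remains open whether a single methyl group on the ring would be enough, or whether both methyl groups are needed for a step of this size. Also unanswered is how the number would respond to other groups on this ring, such as chlorine, methoxy, an amine or a carboxylic acid, and so whether the kind of group matters as well as the number of groups.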